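A few compounds are considered here, and "the series" means these few. Any claim that something is new, unique, unknown or untested is made for them only; others in the source may bear on it.

Among the compounds with values here, compound 2 `C#CCN(C)/N=N/c1nc[nH]c1C(N)=O` carries the highest of the three numbers so far in a functional assay on L1210 cells (Mus musculus) for antiproliferative activity (a lower number here means a less potent compound, a higher number a more potent compound, by a factor of ten per unit of this negative logarithm), giving 3.61. Compound 1 `CCCCCN(C)/N=N/c1nc[nH]c1C(N)=O` gives 3.58 in this assay, a number within the scatter of compound 2, so the two are not separated. Compound 3 `CN(Cc1ccccc1)/N=N/c1ccccc1`, which has a different core, gives 3.03, beyond the scatter below compound 2. Within the data shown here, the only step between two measured compounds that differ in one place is a number 0.03 log units higher from compound 1 to compound 2 (within the scatter), ethynyl in place of butyl on a saturated chain carbon bound to an amine nitrogen.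

Compound 4 `CCCN(C)/N=N/c1nc[nH]c1C(N)=O` differs from compound 2 by ethyl in place of ethynyl on a saturated chain carbon bound to an amine nitrogen. The step from compound 1 to compound 2 bears on this change directly: it altered the same position of the same chain, from butyl through to ethynyl, and moved the number by an amount within the scatter. Propyl sits between butyl and propargyl in that same series, so the chain length and the triple bond have both shown no effect beyond the scatter here. No step beyond the scatter is therefore expected in this assay; the change from compound 2 to compound 4 is estimated at a number 0.01 log units lower from compound 2 to compound 4 (within the scatter). Compound 4 is expected to give 3.6, with a range from 3.25 to 3.95.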

Compound 4, logarithm of the reciprocal of the active concentration, log(1/C): 3.58
For compound 4 the middle estimate is 0.02 log units above the measured one; measured number inside the range.
By their numbers in this assay, from the lowest: compound 3; then compounds 1, 4 and 2 (each within the scatter of the next).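

With compound 4, a saturated chain can be compared directly with propargyl at this position, and this assay shows a number 0.03 log units lower from compound 2 to compound 4 (within the scatter) for ethyl in place of ethynyl. Hydrogen in place of ethyl on a saturated chain carbon, three bonds along the chain from an amine nitrogen, gives no change at the digits printed from compound 1 to compound 4 (within the scatter) in the same assay. Across compounds 1, 2 and 4, neither the triple bond nor these chain changes separate the numbers, and no supporting data bear on why they stay together.

From the compounds shown here alone, whether the shared core keeps this number with anything other than a plain hydrocarbon substituent stays open; a hydroxyl, a carboxylic acid or an amine on the chain would test that, as would a much longer chain. Compound 3 has a different core and adds nothing on this position.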